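The source may report more compounds than this note shows. Statements on the series, on what has been measured and on what is new or still open speak of the compounds shown alone.

Of the compounds shown here, three share one chalcone-like core and have been tested in a functional assay on MCF7 cells (Homo sapiens) for inhibition, read by sulforhodamine B assay, with a stated time of 72 h; a lower number here means a stronger inhibitor, a higher number a weaker inhibitor. Compound 1 `COc1ccc(OC)c(C(=O)/C=C/c2cn(-c3ccccc3)nc2-c2ccsc2)c1` is the reference; in this assay compound 1 gives 400 nM. Compound 2 `COc1ccc(C(=O)/C=C/c2cn(-c3ccccc3)nc2-c2ccsc2)c(OC)c1` carries the change (2,4-dimethoxyphenyl in place of 2,5-dimethoxyphenyl on a carbonyl carbon). In this assay compound 2 gives 9000 nM, so the step of a 23-fold higher number from compound 1 to compound 2 (1.35 log units; beyond the scatter) is large. Compound 3 `COc1ccc(OC)c(C(=O)/C=C/c2cn(-c3ccccc3)nc2-c2cccnc2)c1` differs from compound 1 in its core by pyridin-3-yl in place of thiophen-3-yl on an aromatic carbon. In this assay compound 3 gives 1500 nM, and the step of a 3.8-fold higher number from compound 1 to compound 3 (0.57 log units; beyond the scatter) is modest. Compound 3 thus stands second of the three numbers, nearer to compound 1 than to compound 2.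

Compound 4 `COc1ccc(C(=O)/C=C/c2cn(-c3ccccc3)nc2-c2cccnc2)c(OC)c1` has not yet been measured. It differs from compound 3 by 2,4-dimethoxyphenyl in place of 2,5-dimethoxyphenyl on a carbonyl carbon. This is the same change as that from compound 1 to compound 2, made at the same place, and among the compounds shown it occurs twice in all. For the measured compounds named here, the only measured instance is a 23-fold higher number from compound 1 to compound 2 (1.35 log units; beyond the scatter), a large step in the direction of weaker inhibition. Because compound 3 already gives 1500 nM, compound 4 is expected to land considerably higher, with a step estimated at a 19-fold higher number from compound 3 to compound 4 (1.27 log units; beyond the scatter), somewhat tempered since a single example is the only basis. In this assay compound 4 is estimated to give 28000 nM, with a range expected from 9000 nM to 90000 nM.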

Compound 4, half-maximal inhibitory concentration: 2300 nM
Estimate against measurement, compound 4: 12-fold (1.09 log units) above; measured number outside the range, below it.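

In this assay, 2,4-dimethoxyphenyl in place of 2,5-dimethoxyphenyl on the carbonyl carbon gives a 1.5-fold higher number from compound 3 to compound 4 (0.19 log units; within the scatter) when pyridin-3-yl is present, so the large penalty seen with thiophen-3-yl did not carry over to this core: the same change on two cores in this assay, a 23-fold higher number (1.35 log units; beyond the scatter) from compound 1 to compound 2 and a 1.5-fold higher number (0.19 log units; within the scatter) from compound 3 to compound 4, 15-fold (1.17 log units) apart, beyond the scatter of two such steps Read the other way round, pyridin-3-yl in place of thiophen-3-yl gives a 3.9-fold lower number from compound 2 to compound 4 (0.59 log units; beyond the scatter) when 2,4-dimethoxyphenyl is present, which runs opposite to the step seen with 2,5-dimethoxyphenyl: the same change on two cores in this assay, a 3.8-fold higher number (0.57 log units; beyond the scatter) from compound 1 to compound 3 and a 3.9-fold lower number (0.59 log units; beyond the scatter) from compound 2 to compound 4, 15-fold (1.17 log units) apart, beyond the scatter of two such steps Across these four compounds the two changes therefore do not add up, and the effect of each depends on the other, but with one pair of steps per change this shows neither why they interact nor how either change would behave on any further core.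

The compounds shown leave open whether this dependence persists with another group in place of thiophen-3-yl or pyridin-3-yl, such as a plain phenyl. They also leave open what an amine or a carboxylic acid in place of the methoxy groups would do on either core.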